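Chloro to methyl on compound 2

A few compounds are considered here, and "the series" means these few. Any claim that something is new, unique, unknown or untested is made for them only; others in the source may bear on it.

For the measured compounds named here, compound 2 `O=C(Nc1cnc2ccccc2c1)c1cccc(Cl)c1O` gives 28.4 nM in a functional assay on HUVEC cells (Homo sapiens) for inhibition, read by ELISA and BrdU incorporation (a higher number here means a weaker inhibitor, a lower number a stronger inhibitor), and holds the lower of the two numbers measured so far. Compound 1 `O=C(Nc1cccc2cccnc12)c1ccc(Cl)nc1` gives 141 nM in this assay and so stands above compound 2 by a gap beyond the usual scatter. These two compounds differ in more than one place, so they give no direct guide to a single change. Compound 3 `Cc1cccc(C(=O)Nc2cnc3ccccc3c2)c1O` departs from compound 2 by one change methyl in place of chloro on an aromatic carbon with methyl in place of chloro on an aromatic carbon, ortho to a hydroxy group and meta to a large group. Going by the values given here, no measured pair covers this swap, so the expectation is only tentative. The expected step of a 1.4-fold higher number from compound 2 to compound 3 (0.15 log units; within the scatter) is a small rise in the number, not clearly beyond the scatter. For compound 3 the estimated value is 40 nM with an expected range from 12 nM to 130 nM in these notes.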

Compound 3, half-maximal inhibitory concentration: 35.7 nM
Compound 3: the middle estimate sits 1.1-fold (0.05 log units) above what was measured; the measured number falls inside the stated range.
By their numbers in this assay, from the lowest: compounds 2 and 3 (each within the scatter of the next); then compound 1.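

Methyl in place of chloro on an aromatic carbon, ortho to a hydroxy group and meta to a large group, gives a 1.3-fold higher number from compound 2 to compound 3 (0.10 log units; within the scatter) in this assay, so the two groups cannot be told apart at this position in this assay. For the compounds shown here, this is the first reading of a single change, as compound 1 differs from compound 2 in more than one place and could say nothing about this position. No available data bear on the reason for this result.

The compounds shown leave open whether an amine, a methoxy group or a carboxylic acid at this position would give a similar number. They also leave open what happens when the neighbouring hydroxy group gives way to a hydrogen or a methoxy group, with either chloro or methyl in place.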